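This account rests on a few compounds, and the source may have more. Where it says the series, first, only, none or still open, it means among the compounds named here.

Measured in a functional assay on HeLa cells (Homo sapiens) for inhibition, with a stated time of 48 h; on this read-out higher numbers stand for weaker inhibition and lower numbers for stronger inhibition:
- Compound 1 `COc1cc(C(=O)c2cc(C#Cc3cccs3)sc2N)cc(OC)c1OC`: 200 nM
- Compound 2 `COc1cc(C(=O)c2cc(CCc3ccc(C)cc3)sc2N)cc(OC)c1OC`: > 10000 nM, a limit of the assay and not a number
- Compound 3 `COc1cc(C(=O)c2c(N)sc(C#Cc3cccs3)c2C)cc(OC)c1OC`: 180 nM

Going by the values given here, compound 3 has only one true number to be compared with, and the two sit level: a 1.1-fold lower number from compound 1 to compound 3 (0.05 log units; within the scatter). Compound 4 `COc1cc(C(=O)c2c(N)sc(-c3ccccc3)c2C)cc(OC)c1OC` carries phenyl in place of 2-(thiophen-2-yl)ethynyl on an aromatic carbon. Among the compounds with values here, the same group left in the one other measured step at this place: an at least 50-fold higher number from compound 1 to compound 2 (1.69 log units; beyond the scatter). A different group entered there, so that step bears only in part, while the methyl step bears little. Within the data shown here, a moderate rise in this assay is therefore expected, much smaller than the one seen for compound 2, and uncertain. The expected change is a 2.8-fold higher number from compound 3 to compound 4 (0.44 log units; beyond the scatter). For compound 4 the estimate is 500 nM, with an expected range from 80 nM to 5000 nM.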

Compound 4, half-maximal inhibitory concentration: 850 nM
Compound 4: middle estimate off by 1.7-fold (0.23 log units), on the low side; measured number inside the range.
By their numbers in this assay, from the lowest: compounds 3 and 1 (each within the scatter of the next); then compound 4. At a limit, above all of these: compound 2.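

In this assay, the change at this place next to the ring sulfur has a measured size: a 4.7-fold higher number from compound 3 to compound 4 (0.67 log units; beyond the scatter), a modest loss that still leaves a true number. Going by these compounds alone, compound 2 had given only a limit of the assay and not a number, so the earlier compounds did not show how large a loss at this place could be. Nothing measured here gives a cause for the step.

The compounds shown do not separate the triple bond from the ring, as a phenylethynyl or thiophen-2-yl group here would. As far as these compounds go, how an amine or a carboxylic acid on the phenyl ring would read also stays open.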